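Swapping a Pyridyl Ethenyl Arm for a Methoxyphenyl

The source may report more compounds than this note shows. Statements on the series, on what has been measured and on what is new or still open speak of the compounds shown alone.

Compound 1 `COC(=O)/C=C/c1cccc(N(Cc2ccc(/C=C/c3ccccn3)cc2)C(=O)C2CCCCC2)c1`: 309 nM
Compound 2 `COC(=O)/C=C/c1cccc(N(Cc2ccc(/C=C/c3ccccn3)cc2)C(=O)C(C)C)c1`: 310 nM

Of the compounds shown here, two have been measured in an assay on isolated protein with Bile acid receptor (Homo sapiens) as the target; on this read-out lower numbers stand for an effect already at smaller amounts and higher numbers for an effect only at larger amounts of compound. Compound 1 has the lowest of the two numbers, but compound 2 sits within the scatter of it: a 1.0-fold higher number from compound 1 to compound 2 (0.00 log units; within the scatter). That step touches only the group on the carbonyl carbon, isopropyl in place of cyclohexyl, and it left the number essentially unchanged.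

Compound 3 `COC(=O)/C=C/c1cccc(N(Cc2ccc(-c3ccc(OC)cc3)cc2)C(=O)C2CCCCC2)c1` has not yet been measured. It differs from compound 1 at the opposite end of the shared core: 4-methoxyphenyl in place of 2-(pyridin-2-yl)ethenyl on an aromatic carbon. Among the measured compounds shown here, no measured step bears on this place; the one step known concerns a different part of the molecule, so it says nothing about how the end group matters for the result in this assay. The expectation must therefore rest on compound 1 alone, with a wide range around it. Compound 3 is expected to give 400 nM, between 80 nM and 2000 nM. This estimate means a step of a 1.3-fold higher number from compound 1 to compound 3 (0.11 log units; within the scatter), which is no more than a guess at no change beyond the scatter.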

Compound 3, half-maximal effective concentration: 89 nM
Compound 3: the middle estimate sits 4.5-fold (0.65 log units) above what was measured; low and high end bracket the measured number.
By their numbers in this assay, from the lowest: compound 3; then compounds 1 and 2 (each within the scatter of the next).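

In this assay, the step of a 3.5-fold lower number from compound 1 to compound 3 (0.54 log units; beyond the scatter) shows that the group at this position, on an aromatic carbon para to a large group, can shift the number beyond the scatter, whereas the change on the carbonyl carbon, a 1.0-fold higher number from compound 1 to compound 2 (0.00 log units; within the scatter), stayed within it. The two end groups have the same heavy-atom and hydrogen-bond acceptor counts, so those counts do not separate them, yet the swap changes several features at once: the ring nitrogen goes, the double bond outside the aromatic rings goes, and a methoxy oxygen arrives. Nothing available explains why the number fell, and no single feature can be credited with the change.

From the compounds shown here alone, it remains open which of these features matters: a 2-phenylethenyl arm would keep the double bond without the ring nitrogen, while a plain phenyl would keep the directly attached ring without the methoxy. Also open, going by these compounds, is whether isopropyl on the carbonyl carbon would still match cyclohexyl when 4-methoxyphenyl sits at the other end of the molecule.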